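A few compounds are considered here, and "the series" means these few. Any claim that something is new, unique, unknown or untested is made for them only; others in the source may bear on it.

Compound 1, whose structure is `COc1ccccc1-c1ncnn1-c1cc(OC)c(OC)c(OC)c1`, is one of three close relatives tested in a functional assay on MCF7 cells (Homo sapiens) for antiproliferative activity, read by MTT assay, with a stated time of 72 h; a higher number here means a weaker inhibitor, a lower number a stronger inhibitor. Compound 1 gives only a limit of the assay, > 10000 nM, rather than a number. Compound 2, `COc1ccc(-n2ncnc2-c2cc(OC)c(OC)c(OC)c2)cc1`, carries the 4-methoxyphenyl on a ring nitrogen instead and gives 7400 nM. Compound 3, `COc1cc(-c2ncnn2-c2ccc(Cl)c(Cl)c2)cc(OC)c1OC`, also reaches only a limit, > 10000 nM. Among the measured compounds shown here, the single step measured between neighbours, an at least 1.3-fold higher number from compound 2 to compound 3 (0.13 log units; that floor lies within the scatter), concerns a different exchange and does not match the change studied here; the limit shared by two compounds, (the limit of > 10000 nM in this assay, at which 2 of the 3 values shown sit), means that most of the series sits at the edge of what the assay can report.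

The unmeasured compound 4, `COc1ccc(-c2ncnn2-c2cc(OC)c(OC)c(OC)c2)cc1`, differs from compound 1 by 4-methoxyphenyl in place of 2-methoxyphenyl on an aromatic carbon. For the measured compounds named here, no measured step bears directly on this change, so the expectation rests on compound 2, which holds the same 4-methoxyphenyl at 7400 nM. Compound 4 is therefore estimated to lie near 10000 nM, within a range from 3000 nM to 30000 nM. That expected step, a number no higher from compound 1 to compound 4 (the limit leaves the size open), amounts to no change beyond the scatter.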

Compound 4, half-maximal inhibitory concentration: 360 nM
Beside the measured number, compound 4's estimate is 28-fold (1.44 log units) above it; the whole stated range lies above it.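

Before this result, no measured step touched this position, on an aromatic carbon of the five-membered ring. In this assay, putting 4-methoxyphenyl in place of 2-methoxyphenyl gives an at least 27-fold lower number from compound 1 to compound 4 (1.44 log units; beyond the scatter), and since the two compounds have the same atoms, joined differently, a change in where the methoxy group sits on the phenyl ring is enough to produce a large step. Compound 1 reaches only a limit, > 10000 nM, so this step gives a minimum and its full size stays unknown: the limit of > 10000 nM in this assay, at which 2 of the 4 values shown sit.

The compounds shown leave open whether an amine, or a longer chain such as ethoxy, could stand in place of the methoxy group of compound 4 and keep this activity. They also do not explain why moving the methoxy group makes so large a difference.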